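The compounds below may be only part of what the source reports. "The series", "measured", "known", "first", "only" and "open" are said of these compounds alone.

- Compound 1 `COC(=O)c1ccc(NCc2cncn2Cc2ccc(Cl)cc2)cc1-c1ccccc1`: 25000 nM
- Compound 2 `COc1ccc(NCc2cncn2Cc2ccc(-c3ccccc3)cc2N)cc1-c1ccccc1`: > 1000 nM
- Compound 3 `c1ccc(-c2ccc(Cn3cncc3CNc3cccc(-c4ccccc4)c3)cc2)cc1`: 10000 nM

These three compounds were tested in a toxicity assay on NIH3T3 cells (Mus musculus) for cytotoxicity, read by resazurin assay; on this read-out higher numbers stand for an effect only at larger amounts of compound and lower numbers for an effect already at smaller amounts. Compound 1 stands highest of the two true numbers at 25000 nM. Its nearest neighbour, compound 3, gives a lower 10000 nM, and that gap lies beyond the usual scatter. Compound 2 gives > 1000 nM, which is a limit and not a number.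

The next compound, compound 4 `COC(=O)c1ccc(NCc2cncn2Cc2ccccc2Cl)cc1-c1ccccc1`, has not yet been measured. It keeps the core of compound 1 and changes in one place: 2-chlorophenyl in place of 4-chlorophenyl on a saturated chain carbon bound to an aromatic nitrogen. Here 2-chlorophenyl stands in place of 4-chlorophenyl on a saturated chain carbon bound to an aromatic nitrogen. Going by the values given here, no measured pair shows a change of this kind, so no step beyond the scatter is expected in this assay. The estimate therefore starts from compound 1 at 25000 nM. The estimated change is a 1.3-fold lower number from compound 1 to compound 4 (0.10 log units; within the scatter). For compound 4 the expected value is 20000 nM, with an estimated range from 8000 nM to 50000 nM.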

Compound 4, half-maximal effective concentration: 10000 nM
Beside the measured number, compound 4's estimate is 2.0-fold (0.30 log units) above it; low and high end bracket the measured number.
By their numbers in this assay, from the lowest: compounds 3 and 4 (each within the scatter of the next); then compound 1.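

In this assay, 2-chlorophenyl in place of 4-chlorophenyl on a saturated chain carbon bound to an aromatic nitrogen gives a 2.5-fold lower number from compound 1 to compound 4 (0.40 log units; beyond the scatter) and so an effect on the cells already at a smaller amount of compound. This is the first pair shown that differs in one place, and it shows that the same atoms, joined differently at this one spot, can shift the number beyond the usual scatter, though only modestly. Nothing given here explains why this step occurs.

A single pair on a single core leaves open whether the same step would appear on a different core. It also leaves open where the number would fall with 3-chlorophenyl or 2-fluorophenyl on this same chain carbon.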